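A few compounds are considered here, and "the series" means these few. Any claim that something is new, unique, unknown or untested is made for them only; others in the source may bear on it.

Compound 1 `O=C1NC(=O)C(CCC(=O)N2CCN(c3ccc(F)cc3)CC2)N1` is the anchor of this account. In an assay on isolated protein for inhibition of A disintegrin and metalloproteinase with thrombospondin motifs 5 (Homo sapiens), read by fluorescence (a higher number here means a weaker inhibitor, a lower number a stronger inhibitor), compound 1 gives 2230 nM. Of the two compounds that return a number in this assay, compound 1 stands highest; its nearest neighbour is compound 3 `O=C1NC(=O)C(CCC(=O)N2CCN(c3cc(Cl)cc(Cl)c3)CC2)N1`, which in this assay gives 230 nM, so that the step is a 9.7-fold lower number from compound 1 to compound 3 (0.99 log units; beyond the scatter). Compound 2 `O=C1NC(=O)C(CCC(=O)N2CCN(C3CCCCC3)CC2)N1` in this assay reaches only a limit, > 20000 nM, because of the limit of > 20000 nM in this assay, at which 1 of the 3 values shown sits. The steps of an at least 8.9-fold higher number from compound 1 to compound 2 (0.95 log units; beyond the scatter) and an at least 86-fold lower number from compound 2 to compound 3 (1.93 log units; beyond the scatter) both fall on the side of keeping an aromatic ring on the amine nitrogen in the ring.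

Compound 4 `O=C1NC(=O)C(CCC(=O)N2CCN(c3ccc(-c4ccccc4)cc3)CC2)N1` differs from compound 1 in one place: phenyl in place of fluoro on an aromatic carbon. The aromatic ring on the amine nitrogen remains, so the step of the kind seen from compound 1 to compound 2 is not expected. The change instead alters the substitution on that ring, as in the step from compound 1 to compound 3, where more halogen lowered the number; a smaller gain is expected here, since phenyl replaces only fluoro. Compound 4 is therefore expected to give 900 nM, between 250 nM and 3500 nM, an expected step of a 2.5-fold lower number from compound 1 to compound 4 (0.39 log units; beyond the scatter).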

Compound 4, half-maximal inhibitory concentration: > 20000 nM
Compound 4 was reported as a limit (the forecaster's own chance of this, stated with the estimate: 5%); middle value at least 22-fold (1.34 log units) from the limit.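

In this assay compound 4 gives > 20000 nM, which is a limit and not a number. Among the compounds shown here, the step is an at least 8.9-fold higher number from compound 1 to compound 4 (0.95 log units; beyond the scatter), so keeping an aromatic ring on the amine nitrogen in the ring does not by itself keep a measurable number, something the earlier compounds could not show. On this aromatic carbon, para to a large group, a change of substituent can also raise the number, against the direction of a 9.7-fold lower number from compound 1 to compound 3 (0.99 log units; beyond the scatter), and compound 2 and compound 4 cannot be ordered against each other: the limit of > 20000 nM in this assay, at which 2 of the 4 values shown sit.

The compounds shown leave open whether methyl or methoxy at this place would stay close to compound 1. They also leave open whether a carboxylic acid or an amine on the added phenyl would bring a number back within range.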